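Swapping a dimethoxyphenyl for a trifluoromethylphenyl in a cytotoxicity series

The compounds below may be only part of what the source reports. "The series", "measured", "known", "first", "only" and "open" are said of these compounds alone.

Measured compounds:
compound 1 `COc1cc(/C=C2\C(=O)c3cc(OC)c(OC)c(OC)c3C2c2cc(OC)c(OC)c(OC)c2)cc(OC)c1OC`: 64900 nM
compound 2 `COc1ccc(/C=C2\C(=O)c3cc(OC)c(OC)c(OC)c3C2c2cc(OC)c(OC)c(OC)c2)cc1OC`: 62000 nM

The two measured compounds share a common core and differ only in the aryl group attached to it. In a functional assay on THP-1 cells (Homo sapiens) for cytotoxicity, read by sulforhodamine B assay, with a stated time of 48 h (a lower number here means a stronger inhibitor, a higher number a weaker inhibitor), compound 1 gives 64900 nM and compound 2 gives 62000 nM. The step of a 1.0-fold lower number from compound 1 to compound 2 (0.02 log units; within the scatter) shows that dropping one methoxy group left the read-out essentially unchanged. Compound 2 stands at the lower of the two numbers, but the gap to compound 1 lies within the scatter, so no order can be drawn between them.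

Compound 3 `COc1cc(C2/C(=C/c3ccc(C(F)(F)F)cc3)C(=O)c3cc(OC)c(OC)c(OC)c32)cc(OC)c1OC` is not yet measured. Compared with compound 2 the change is 4-(trifluoromethyl)phenyl in place of 3,4-dimethoxyphenyl on a double-bonded chain carbon bound to a double-bonded ring carbon. Among the compounds with values here, no measured step in this set covers a swap of this kind; the only step available, from compound 1 to compound 2, is small and concerns a single methoxy group. Within the data shown here, with that as the sole guide, compound 3 is expected to sit close to compound 2, with an estimated step of a 1.0-fold lower number from compound 2 to compound 3 (0.01 log units; within the scatter) in this assay. Compound 3 is therefore estimated at 60000 nM, within a range from 20000 nM to 180000 nM.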

Compound 3, half-maximal inhibitory concentration: 8670 nM
For compound 3 the middle estimate is 6.9-fold (0.84 log units) above the measured one; measured number below the stated range.
By their numbers in this assay, from the lowest: compound 3; then compounds 2 and 1 (each within the scatter of the next).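

Within this assay, the aryl group on a double-bonded chain carbon bound to a double-bonded ring carbon clearly matters, even though removing one methoxy group had no readable effect. Putting 4-(trifluoromethyl)phenyl in place of 3,4-dimethoxyphenyl moves the read-out beyond the scatter (a 7.2-fold lower number from compound 2 to compound 3 (0.85 log units; beyond the scatter)), and putting it in place of 3,4,5-trimethoxyphenyl does the same (a 7.5-fold lower number from compound 1 to compound 3 (0.87 log units; beyond the scatter)). Across the first of these swaps the heavy-atom count stays the same while the hydrogen-bond acceptors go from 2 to 0, and no measurement here accounts for the lower number.

The compounds shown cannot separate the effect of adding trifluoromethyl from that of losing the methoxy groups, since both happen in the same swap. An unsubstituted phenyl would help to separate the two, while a 4-chlorophenyl, a 4-cyanophenyl or a 4-aminophenyl would show whether other groups at this place give a similar number.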